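The source may report more compounds than this note shows. Statements on the series, on what has been measured and on what is new or still open speak of the compounds shown alone.

Compound 1, `CCC[C@H]1O[C@H](COCc2ccccc2)[C@@H](OCc2ccccc2)[C@H](OCc2ccccc2)[C@H]1O`, and compound 2, `CC(C)C[C@H]1O[C@H](COCc2ccccc2)[C@@H](OCc2ccccc2)[C@H](OCc2ccccc2)[C@H]1O`, share one core, while compound 3, `CCC[C@@H]1O[C@H](COCc2ccccc2)[C@@H](OCc2ccccc2)[C@H](OCc2ccccc2)C1=O`, and compound 4, `CC(C)C[C@@H]1O[C@H](COCc2ccccc2)[C@@H](OCc2ccccc2)[C@H](OCc2ccccc2)C1=O`, share another; how the two cores differ is not broken down here. In a functional assay on HeLa cells (Homo sapiens) for antiproliferative activity, read by sulforhodamine B assay (on this read-out higher numbers stand for weaker inhibition of growth and lower numbers for stronger inhibition of growth), compound 1 gives 17400 nM. In this assay compound 2 gives 43900 nM. The change between them, (methyl in place of hydrogen on a saturated chain carbon bound to two saturated chain carbons), produced a 2.5-fold higher number from compound 1 to compound 2 (0.40 log units; beyond the scatter). Compound 3 sits at a limit of this assay, > 50000 nM, which is the line at which one of the three known values rests (the limit of > 50000 nM in this assay, at which 1 of the 3 values shown sits). Compound 4 differs from compound 3 by the same change, (methyl in place of hydrogen on a saturated chain carbon bound to two saturated chain carbons), made on the other core. Since the earlier step of a 2.5-fold higher number from compound 1 to compound 2 (0.40 log units; beyond the scatter) moved the number upward, and compound 3 already stands at the limit, compound 4 is expected to remain at or beyond that limit, so the expected step from compound 3 to compound 4 is a step that the limit leaves unreadable from compound 3 to compound 4. On this basis compound 4 is estimated at 100000 nM, most likely reported only as a limit.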

Compound 4, concentration for 50% growth inhibition: > 50000 nM
Compound 4: only a limit was reported (the forecaster's own chance of this, stated with the estimate: 85%); the middle value lies beyond the limit too.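

Compound 4 gives > 50000 nM in this assay and this is a limit of the assay. Compound 3 also rests at a limit, so no step can be read between compound 3 and compound 4: the limit of > 50000 nM in this assay, at which 2 of the 4 values shown sit. The compounds shown leave open whether methyl in place of hydrogen alters growth inhibition on the core of compound 3 as it did on the core of compound 1.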